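This account rests on a few compounds, and the source may have more. Where it says the series, first, only, none or still open, it means among the compounds named here.

Compound 3 `CCc1ccc(S(=O)(=O)N2CCC(N3CCC(C)CC3)CC2)cc1` carries a 4-ethylphenyl group on its sulfonyl sulfur, and in a functional assay on DLD-1 cells (Homo sapiens) for antiproliferative activity, read by CellTiter-Glo, with a stated time of 72 h (on this read-out higher numbers stand for weaker inhibition and lower numbers for stronger inhibition), compound 3 gives only a limit of > 5000 nM, not a number. The two related compounds for which numbers exist are compound 1 `CC1CCN(C2CCN(S(=O)(=O)c3ccc(C#N)cc3)CC2)CC1`, which in this assay gives 2800 nM, and compound 2 `CC1CCN(C2CCN(S(=O)(=O)c3cccc(N)c3)CC2)CC1`, which gives 3400 nM. The step from compound 1 to compound 2, a 1.2-fold higher number from compound 1 to compound 2 (0.08 log units; within the scatter), swaps one aryl group for another on the sulfonyl sulfur and changes little. Toward compound 3 the picture is similar: an at least 1.7-fold higher number from compound 1 to compound 3 (0.25 log units; that floor lies within the scatter) and an at least 1.4-fold higher number from compound 2 to compound 3 (0.16 log units; that floor lies within the scatter), both of them bounded only by the limit described under (the limit of > 5000 nM in this assay, at which 1 of the 3 values shown sits).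

Compound 4 `CC1CCN(C2CCN(S(=O)(=O)c3ccc(Cl)c(Cl)c3)CC2)CC1` is not yet measured. The change from compound 3 to compound 4 is 3,4-dichlorophenyl in place of 4-ethylphenyl on a sulfonyl sulfur. Among the measured compounds shown here, the steps that bear on it are the three aryl swaps on the same sulfonyl sulfur, and none of them moves the number beyond the scatter, although compound 3 sits at a limit and so sets only a floor. Compound 4 is therefore expected to stay close to compound 3, a step of about a number no higher from compound 3 to compound 4 (the limit leaves the size open). The estimate for compound 4 in this assay is 5000 nM, with a range from 2000 nM to 15000 nM, and a real chance that again only a limit is reported.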

Compound 4, half-maximal inhibitory concentration: 2.9 nM
Estimate against measurement, compound 4: 1700-fold (3.24 log units) above; the measured number lies below the stated range.
By their numbers in this assay, from the lowest: compound 4; then compounds 1 and 2 (each within the scatter of the next). At a limit, above all of these: compound 3.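

On the sulfonyl sulfur, the earlier aryl swaps had suggested a position that tolerates change without much effect, but in this assay the 3,4-dichlorophenyl group gives a 970-fold lower number from compound 1 to compound 4 (2.98 log units; beyond the scatter) and a 1200-fold lower number from compound 2 to compound 4 (3.07 log units; beyond the scatter), while the step between those two earlier groups was only a 1.2-fold higher number from compound 1 to compound 2 (0.08 log units; within the scatter). The change from 4-ethylphenyl, a group with the same heavy-atom count as 3,4-dichlorophenyl, reads as an at least 1700-fold lower number from compound 3 to compound 4 (3.23 log units; beyond the scatter), so that count does not separate the two groups. Compound 3 stands at a limit, which makes this step a floor and leaves its true size unknown: the limit of > 5000 nM in this assay, at which 1 of the 4 values shown sits.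

The compounds shown leave open whether both chlorines are needed for the step, since none of them carries a phenyl group with a single chlorine, and whether bromine or methyl groups in their place would give a similar number. They also leave open whether the step would hold with a change elsewhere in the shared core, and they give no measured property that would explain it.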